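A Longer Acid Chain in Place of the Allyl Group

The source may report more compounds than this note shows. Statements on the series, on what has been measured and on what is new or still open speak of the compounds shown alone.

Three compounds share one core and differ only in the group attached through an oxygen on that core. Compound 1 `O=c1c(-c2ccc(O)cc2)coc2cc(OCCCCCCO)ccc12` carries a chain ending in a hydroxyl, and in an assay (Cricetulus griseus) for inhibition of aldehyde dehydrogenase, mitochondrial (Homo sapiens) (a higher number here means a weaker inhibitor, a lower number a stronger inhibitor), compound 1 gives 120 nM. Compound 2 `O=C(O)COc1ccc2c(=O)c(-c3ccc(O)cc3)coc2c1` carries a short chain ending in a carboxylic acid, and in this assay compound 2 gives 1200 nM. Compound 3 `C=CCOc1ccc2c(=O)c(-c3ccc(O)cc3)coc2c1` carries an allyl group, and in this assay compound 3 gives 180 nM. Compound 3 thus stands second highest of the three numbers; the nearer gap is within the scatter, as a 1.5-fold higher number from compound 1 to compound 3 (0.18 log units; within the scatter) shows, while the further gap is beyond it, as a 6.7-fold lower number from compound 2 to compound 3 (0.82 log units; beyond the scatter) shows.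

Compound 4 `O=C(O)CCCCCCOc1ccc2c(=O)c(-c3ccc(O)cc3)coc2c1` is not yet measured. It differs from compound 3 by 5-carboxypentyl in place of vinyl on a saturated chain carbon bound to an oxygen on an aromatic ring. Among the measured compounds shown here, two measured steps bear on this. a 6.7-fold lower number from compound 2 to compound 3 (0.82 log units; beyond the scatter) shows that a carboxy on the saturated chain carbon bound to an oxygen on the aromatic ring gives a modestly weaker inhibitor. a 1.5-fold higher number from compound 1 to compound 3 (0.18 log units; within the scatter) shows that a chain of similar length ending in a hydroxyl changes little. Compound 4 places its acid at the end of a long chain, between these two cases, so a modest step toward a higher number is expected: a 2.2-fold higher number from compound 3 to compound 4 (0.35 log units; beyond the scatter). Compound 4 is estimated at 400 nM, with a range from 120 nM to 1500 nM.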

Compound 4, half-maximal inhibitory concentration: 50 nM
Estimate against measurement, compound 4: 8.0-fold (0.90 log units) above; the whole stated range lies above it.
By their numbers in this assay, from the lowest: compound 4; then compounds 1 and 3 (each within the scatter of the next); then compound 2.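

At this position a carboxylic acid does not in itself make a weaker inhibitor: going from the allyl group to the 6-carboxyhexyl chain gives a stronger inhibitor (a 3.6-fold lower number from compound 3 to compound 4 (0.56 log units; beyond the scatter)), and compound 4 has the lowest number of the set. What the acid does depends strongly on the chain that carries it, since replacing the short acid chain with the long one gives the largest step seen among these compounds (a 24-fold lower number from compound 2 to compound 4 (1.38 log units; beyond the scatter)). Among the compounds shown here, the long chains also provide the first direct comparison of the two end groups at the same length, and carboxy in place of hydroxy gives a stronger inhibitor (a 2.4-fold lower number from compound 1 to compound 4 (0.38 log units; beyond the scatter)).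

Nothing shown here explains why the long acid chain does better than the other groups. Acid chains of intermediate length, or a still longer acid chain, would show how potency changes with length, while an amine or an amide at the end of the long chain would test whether the gain over the hydroxyl is specific to the carboxylic acid.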